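The source may report more compounds than this note shows. Statements on the series, on what has been measured and on what is new or still open speak of the compounds shown alone.

Compound 1 `COc1cccc(-c2c(C)n(Cc3c(F)cccc3F)c(=O)n(C[C@@H](N)CCc3ccccc3)c2=O)c1F`: 965 nM. Compound 2 `COc1cccc(-c2c(C)n(Cc3c(F)cccc3F)c(=O)n(C[C@H](NC(C)C)C3CCCCC3)c2=O)c1F`: 23 nM. Compound 3 `COc1cccc(-c2c(C)n(Cc3c(F)cccc3F)c(=O)n(C[C@H](NC(C)C)C3CCCC3)c2=O)c1F`: 12 nM.

In an assay on HEK293 cells for binding affinity to Gonadotropin-releasing hormone receptor (Homo sapiens), read by radioligand binding (a lower number here means a stronger inhibitor, a higher number a weaker inhibitor), compound 3 gives the lowest of the three numbers, though its separation from compound 2 is small: a 1.9-fold lower number from compound 2 to compound 3 (0.28 log units; within the scatter). Compound 4 `COc1cccc(-c2c(C)n(Cc3c(F)cccc3F)c(=O)n(C[C@H](N)C3CCCC3)c2=O)c1F` differs from compound 3 by hydrogen in place of isopropyl on an amine nitrogen, which reads isopropylamino to amino. Within the data shown here, no measured step isolates this change. Among the measured compounds shown here, the steps of a 42-fold lower number from compound 1 to compound 2 (1.62 log units; beyond the scatter) and an 80-fold lower number from compound 1 to compound 3 (1.91 log units; beyond the scatter) both pair the amino-to-isopropylamino change with a switch from 1-amino-3-phenylpropyl to a cycloalkyl group, so they bear on it only in part; compound 1, the one compound carrying amino, gives the highest number. A rise in this assay is therefore expected for compound 4, estimated as a 7.5-fold higher number from compound 3 to compound 4 (0.88 log units; beyond the scatter). Compound 4 is expected near 90 nM, between 20 nM and 400 nM.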

Compound 4, inhibition constant: 10 nM
Compound 4: the middle estimate sits 9.0-fold (0.95 log units) above what was measured, and the stated range ends above it.
By their numbers in this assay, from the lowest: compounds 4, 3 and 2 (each within the scatter of the next, the first and the last beyond it); then compound 1.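

In this assay taking isopropyl off the amine nitrogen of the cyclopentyl compound leaves the number within the scatter (a 1.2-fold lower number from compound 3 to compound 4 (0.08 log units; within the scatter)), so here the free amino group is compatible with a low number. Compound 1 also carries amino, so the amino group alone does not set its high number: the change to amino(cyclopentyl)methyl gives a large step (a 97-fold lower number from compound 1 to compound 4 (1.98 log units; beyond the scatter)), while the step that also alters the ring and the nitrogen substituent is modest (a 2.3-fold lower number from compound 2 to compound 4 (0.36 log units; beyond the scatter)). No evidence explains these results. Going by these compounds, whether amino behaves the same way alongside cyclohexyl stays open, as does the effect of a methyl or benzyl group on this nitrogen.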